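Compound 2 to compound 4: replacing thiophen-2-yl

The compounds below may be only part of what the source reports. "The series", "measured", "known", "first", "only" and "open" are said of these compounds alone.

In a functional assay on HL-60 cells (Homo sapiens) for inhibition, read by CCK-8 assay, with a stated time of 48 h, tested at 20 uM (a lower number here means less inhibition of growth, a higher number more inhibition of growth at the concentration tested), compound 2 (`N#C/C(=C\c1ccccc1OS(=O)(=O)c1ccc([N+](=O)[O-])cc1)C(=O)Nc1nnc(-c2cccs2)s1`) gives 23%, the lowest of the three measured numbers. Compound 3 (`N#C/C(=C\c1ccccc1OS(=O)(=O)c1ccccc1[N+](=O)[O-])C(=O)Nc1nnc(Cc2ccc(F)cc2)s1`) gives 35%, and compound 1 (`COc1ccc(S(=O)(=O)Oc2ccccc2/C=C(\C#N)C(=O)Nc2nnc(-c3cccs3)s2)cc1`) gives 67%. Both lie beyond the scatter from compound 2.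

The next structure is compound 4 (`N#C/C(=C\c1ccccc1OS(=O)(=O)c1ccc([N+](=O)[O-])cc1)C(=O)Nc1nnc(Cc2cccc(F)c2)s1`), with 3-fluorobenzyl in place of thiophen-2-yl on an aromatic carbon. Within the data shown here, no measured step covers this exchange. Among the measured compounds shown here, the only single-place step, a number 44 percentage points lower from compound 1 to compound 2 (beyond the scatter), is large, but it concerns nitro in place of methoxy at another place and sets no size for this one. For the measured compounds named here, compound 3, at 35%, is the only measured compound with a fluorobenzyl group, but it differs from compound 2 in more than one place, so it is only a weak hint of a modest rise.

A small upward step is expected, estimated as a number 8 percentage points higher from compound 2 to compound 4 (within the scatter). For compound 4 the expected value is 31%, with an estimated range of 14% to 50%.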

Compound 4, percent growth inhibition at one concentration: 18%
Beside the measured number, compound 4's estimate is 13 percentage points above it, within the range that was stated.
By their numbers in this assay, from the lowest: compounds 4 and 2 (each within the scatter of the next); then compound 3; then compound 1.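

At this position, 3-fluorobenzyl in place of thiophen-2-yl reads in this assay as a number 5 percentage points lower from compound 2 to compound 4 (within the scatter), the first step measured at this aromatic carbon. The carbon next to the ring nitrogen and the ring sulfur therefore takes a six-membered aromatic ring of carbon only, with 8 heavy atoms, in place of a five-membered aromatic ring with 1 hetero atom, with 5 heavy atoms, and the read-out stays within the scatter. No measurement at hand bears on why this exchange leaves the number within the scatter.

On these data alone, it remains open whether the same exchange reads alike with methoxy in place of nitro, the background of compound 1. Also open, as far as these compounds go, is how an amine, a carboxylic acid or a longer chain on this aromatic carbon would read in this assay.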